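The compounds below may be only part of what the source reports. "The series", "measured", "known", "first", "only" and "open" are said of these compounds alone.

Working notes on the series. Cytotoxicity is followed in a functional assay on HepG2 cells (Homo sapiens) for cytotoxicity, read by MTT assay, with a stated time of 48 h; on this read-out higher numbers stand for weaker inhibition and lower numbers for stronger inhibition. Compound 1 `O=C(CSc1nnc(-c2ccncc2)o1)N/N=C/c1ccc(Cl)cc1` gives 15700 nM in this assay. Compound 2 `O=C(CSc1nnc(-c2ccncc2)o1)N/N=C/c1cccc(F)c1` gives 19500 nM in this assay. Compound 3 `O=C(CSc1nnc(-c2ccncc2)o1)N/N=C/c1cccc(C(F)(F)F)c1` gives 6520 nM in this assay. Compound 2 serves as the point of reference. Against compound 1 the step is a 1.2-fold higher number from compound 1 to compound 2 (0.09 log units; within the scatter), so the two cannot be ordered. Against compound 3 the step is a 3.0-fold lower number from compound 2 to compound 3 (0.48 log units; beyond the scatter), so compound 2 stands apart only from compound 3, at the weaker end of what the three numbers resolve.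

Compound 4 `O=C(CSc1nnc(-c2ccncc2)o1)N/N=C/c1cc(Br)cc(Br)c1O` has not been measured. Its difference from compound 2 is 3,5-dibromo-2-hydroxyphenyl in place of 3-fluorophenyl on a carbon with a double bond to nitrogen. Of the two measured steps, only a 3.0-fold lower number from compound 2 to compound 3 (0.48 log units; beyond the scatter) keeps the ring in place and changes a group on it, and that step was modest; a 1.2-fold higher number from compound 1 to compound 2 (0.09 log units; within the scatter) exchanged one halogen-bearing ring for another and stayed within the scatter. Neither step brings in a hydroxyl or a second halogen, so the present change is covered only loosely. The expectation for compound 4 is a modest lower number in this assay, a 2.4-fold lower number from compound 2 to compound 4 (0.39 log units; beyond the scatter), with wide uncertainty on either side. Compound 4 is therefore estimated at 8000 nM, with an expected range from 2500 nM to 25000 nM.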

Compound 4, half-maximal inhibitory concentration: 6540 nM
Beside the measured number, compound 4's estimate is 1.2-fold (0.09 log units) above it; low and high end bracket the measured number.
By their numbers in this assay, from the lowest: compounds 3 and 4 (each within the scatter of the next); then compounds 1 and 2 (each within the scatter of the next).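

In this assay, the carbon with a double bond to nitrogen carries 3,5-dibromo-2-hydroxyphenyl with a result of a 3.0-fold lower number from compound 2 to compound 4 (0.47 log units; beyond the scatter), and the same exchange gives a 2.4-fold lower number from compound 1 to compound 4 (0.38 log units; beyond the scatter), so the lower number holds against both the 3-fluorophenyl and the 4-chlorophenyl compounds. Among the compounds shown here, this is the first ring with a hydrogen-bond donor and acceptor, and compound 3 at 6520 nM and compound 4 at 6540 nM lie within the scatter of each other, so two differently substituted rings at this place cannot be ordered in this read-out. No supporting measurement is available to explain the shift.

The compounds shown leave open whether the hydroxyl or the bromines account for the step, as none of them carries one without the other. Also open, on these data alone, is how a methoxy in place of the hydroxyl, or an amine or a carboxylic acid on this ring, would compare with compound 3 and compound 4.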